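Methyl on the shared core: a step from compound 1

This account rests on a few compounds, and the source may have more. Where it says the series, first, only, none or still open, it means among the compounds named here.

Compound 1, `C/N=C(/NC#N)NCCCn1nc(-c2ccccc2)ccc1=O`, in a functional assay on the whole organism (stomach) with Rattus norvegicus as the target (a higher number here means that more compound is needed for the effect, a lower number that less compound is needed), gives > 100 mg/kg, which is a limit of the assay and not a number.
Compound 2, `CC/N=C(/NC#N)NCCCn1nc(-c2ccccc2)ccc1=O`, gives 78.3 mg/kg.
Compound 3, `N/C(S)=N/CCCCn1nc(-c2ccccc2)ccc1=O`, gives 36.3 mg/kg.

Compound 1 therefore stands only at a limit, not at a measured number; of the three values shown, it is the one sitting there (the limit of > 100 mg/kg in this assay, at which 1 of the 3 values shown sits). Compound 4, `C/N=C(/NC#N)NCCCn1nc(-c2ccccc2)cc(C)c1=O`, differs from compound 1 by methyl in place of hydrogen on an aromatic carbon. All three measured steps change the side chain, not the shared core: an at least 1.2-fold lower number from compound 1 to compound 2 (0.10 log units; that floor lies within the scatter); an at least 2.7-fold lower number from compound 1 to compound 3 (0.44 log units; beyond the scatter); a 2.2-fold lower number from compound 2 to compound 3 (0.33 log units; beyond the scatter). None of them alters the ring that compound 4 changes, so none bears directly on this step. The nearest in kind is the addition of a methyl in an at least 1.2-fold lower number from compound 1 to compound 2 (0.10 log units; that floor lies within the scatter), which stayed within the scatter. A step of no more than the scatter is therefore expected in this assay, in either direction, as a step that the limit leaves unreadable from compound 1 to compound 4. Compound 4 is estimated at 150 mg/kg, in the range 60 mg/kg to 400 mg/kg, and is expected most likely to return a limit as well.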

Compound 4, dose for half-maximal effect: > 100 mg/kg
Compound 4: only a limit was reported; the forecaster's own chance of this, stated with the estimate: 70%; the middle value lies beyond the limit too.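

Compound 1 and compound 4 both sit at a limit of the assay and not at a number, so no step can be read for the methyl on the aromatic carbon: the limit of > 100 mg/kg in this assay, at which 2 of the 4 values shown sit. On these data alone, whether this methyl raises, lowers or leaves unchanged the dose needed in this assay stays open.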